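The compounds below may be only part of what the source reports. "The series", "measured", "known", "first", "only" and "open" are said of these compounds alone.

Compounds measured:
compound 1, `CCCN(CC[C@H]1CC[C@H](NC(=O)/C=C/c2ccc(F)cc2)CC1)[C@H]1CCc2nc(N)sc2C1`, 1 nM
compound 2, `CCCN(CC[C@H]1CC[C@H](NC(=O)c2ccccc2-n2cccn2)CC1)[C@H]1CCc2nc(N)sc2C1`, 2 nM

Among the measured compounds shown here, in an assay on brain for displacement of a labelled ligand from D(3) dopamine receptor (Rattus norvegicus) (on this read-out lower numbers stand for stronger inhibition and higher numbers for weaker inhibition), compound 2 gives 2 nM, and the only step to it, a 2.0-fold higher number from compound 1 to compound 2 (0.30 log units; within the scatter), is within the scatter, so the two numbers cannot be ordered. Compound 3, `CCCN(CC[C@H]1CC[C@H](NC(=O)c2ccc(-n3cncn3)cc2)CC1)[C@H]1CCc2nc(N)sc2C1`, differs from compound 2 by 4-(1H-1,2,4-triazol-1-yl)phenyl in place of 2-(1H-pyrazol-1-yl)phenyl on a carbonyl carbon. For the measured compounds named here, only that one measured step bears on this change, and it shows the group on the carbonyl carbon altered without a shift beyond the scatter. The expected step of a 1.5-fold higher number from compound 2 to compound 3 (0.18 log units; within the scatter) is therefore small, in no fixed direction. Compound 3 is estimated at 3 nM, ranging from 1 nM to 10 nM.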

Compound 3, inhibition constant: 2.4 nM
Compound 3: middle estimate off by 1.3-fold (0.10 log units), on the high side, within the range that was stated.
By their numbers in this assay, from the lowest: compounds 1, 2 and 3 (each within the scatter of the next, the first and the last beyond it).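

In this assay the step of a 1.2-fold higher number from compound 2 to compound 3 (0.08 log units; within the scatter) shows that 4-(1H-1,2,4-triazol-1-yl)phenyl can replace 2-(1H-pyrazol-1-yl)phenyl on the carbonyl carbon with no readable shift. Set against 2-(4-fluorophenyl)ethenyl, the same position now gives its first step beyond the scatter, though only a modest one: a 2.4-fold higher number from compound 1 to compound 3 (0.38 log units; beyond the scatter). Nothing available here accounts for either step. The compounds shown leave open how an amine or a carboxylic acid on this aromatic group would read in this assay.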